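The source may hold more compounds than are shown below. What is called first, only, known or untested is meant among the compounds shown, and "the series" means these compounds.

Compound 3 `COc1ccc(/C=C/C(=O)Nc2cc(C(=O)c3cc(OC)c(OC)c(OC)c3)cc(OC)c2OC)cc1OC` stands second highest among the three numbers gathered in a functional assay on PC-3 cells (Homo sapiens) for cytotoxicity, read by MTT assay, with a stated time of 72 h (on this read-out lower numbers stand for stronger inhibition and higher numbers for weaker inhibition), where compound 3 gives 5400 nM. Its nearest neighbour is compound 1 `COc1ccc(C(=O)c2cc(OC)c(OC)c(OC)c2)cc1NC(=O)/C=C/c1ccc(OC)c(OC)c1`, which in this assay gives 7500 nM, and furthest from it lies compound 2 `COc1ccc(C(=O)c2cc(OC)c(OC)c(OC)c2)cc1NC(=O)/C=C/c1ccc(C(F)(F)F)cc1`, which in this assay gives 3500 nM; both gaps fall within the scatter, so no order can be read among the three. Compound 3 differs from compound 1 only in carrying a methoxy in place of hydrogen on an aromatic carbon, and that step, a 1.4-fold lower number from compound 1 to compound 3 (0.14 log units; within the scatter), sits within the scatter. Compound 4 `COc1cc(C(=O)c2cc(OC)c(OC)c(OC)c2)cc(NC(=O)/C=C/c2ccc(F)cc2)c1OC` is the next member, and its change from compound 3 is 4-fluorophenyl in place of 3,4-dimethoxyphenyl on a double-bonded chain carbon bound to a double-bonded chain carbon. Within the data shown here, one measured step bears on it: the exchange of the same 3,4-dimethoxyphenyl for 4-(trifluoromethyl)phenyl on the core of compound 1 gave a 2.1-fold lower number from compound 1 to compound 2 (0.33 log units; beyond the scatter). Among the measured compounds shown here, no measured step tests 4-fluorophenyl itself, and the core of compound 3 carries the methoxy that compound 1 lacks, so the analogy is loose. A modest lowering of the number is therefore expected, and compound 4 is estimated to give 3200 nM in this assay, in the range 1500 nM to 7000 nM, amounting to an expected step of a 1.7-fold lower number from compound 3 to compound 4 (0.23 log units; within the scatter).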

Compound 4, half-maximal inhibitory concentration: 4100 nM
For compound 4 the middle estimate is 1.3-fold (0.11 log units) below the measured one; low and high end bracket the measured number.
By their numbers in this assay, from the lowest: compounds 2, 4, 3 and 1 (each within the scatter of the next, the first and the last beyond it).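

In this assay the exchange of 3,4-dimethoxyphenyl for 4-fluorophenyl on a double-bonded chain carbon bound to a double-bonded chain carbon gives a 1.3-fold lower number from compound 3 to compound 4 (0.12 log units; within the scatter) and so leaves no difference that can be read. On the core of compound 3, then, this position accepts a smaller group that carries fluorine and no oxygen, with no effect distinguishable from the usual scatter. Among these compounds, the only earlier exchange here, to 4-(trifluoromethyl)phenyl on the core of compound 1, gave a 2.1-fold lower number from compound 1 to compound 2 (0.33 log units; beyond the scatter), so the new step shows that losing 3,4-dimethoxyphenyl does not bring a step beyond the scatter in every case, and no measurement at hand explains the result.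

Compound 2 and compound 4 differ in more than one place, so the compounds shown cannot separate the effect of 4-fluorophenyl from that of 4-(trifluoromethyl)phenyl on one core, or say whether the extra methoxy of compound 3 alters the response. Also open, on these data alone, is how this position behaves with a 4-aminophenyl group, a 4-carboxyphenyl group or a saturated cyclohexyl ring in place of the aromatic ring.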